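A few compounds are considered here, and "the series" means these few. Any claim that something is new, unique, unknown or untested is made for them only; others in the source may bear on it.

Compound 1, `COc1ccc(-c2cn(C[C@H]3COC(C)(C)O3)nn2)cc1`, in a functional assay on B16 cells (Mus musculus) for cytotoxicity, read by MTT assay, with a stated time of 48 h (a lower number here means a stronger inhibitor, a higher number a weaker inhibitor), gives > 100000 nM, which is a limit of the assay rather than a number.
Compound 2, `CC1(C)OC[C@H](Cn2cc(-c3ccc([N+](=O)[O-])cc3)nn2)O1`, gives > 100000 nM, again only a limit.
Compound 3, `CC1(C)OCC(Cn2cc(-c3ccc(C(F)(F)F)cc3)nn2)O1`, gives 13500 nM.

Compound 2 thus stands at a limit, not at a measured number. The step that the two limits leave unreadable from compound 1 to compound 2 is left unreadable by the two limits, and the limit of > 100000 nM in this assay, at which 2 of the 3 values shown sit, is the common ground of two of the three values shown. Compound 4, `O=[N+]([O-])c1ccc(-c2cn(Cc3ccccc3)nn2)cc1`, differs from compound 2 by phenyl in place of 2,2-dimethyl-1,3-dioxolan-4-yl on a saturated chain carbon bound to an aromatic nitrogen. Among the compounds with values here, no measured step touches this change, so neither its direction nor its size can be read from the data. Compound 4 is expected to come out near 80000 nM, within 15000 nM to 300000 nM, and the expected step of an at least 1.2-fold lower number from compound 2 to compound 4 (0.09 log units; that floor lies within the scatter) is hardly more than a guess from the limit.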

Compound 4, half-maximal inhibitory concentration: 5120 nM
Estimate against measurement, compound 4: 16-fold (1.19 log units) above; the whole stated range lies above it.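

Replacing 2,2-dimethyl-1,3-dioxolan-4-yl with phenyl on a saturated chain carbon bound to an aromatic nitrogen gives the first readable effect at this position: in this assay the change produces an at least 19-fold lower number from compound 2 to compound 4 (1.29 log units; beyond the scatter) while the nitro group stays in place. The group at this position can therefore shift the result beyond the scatter. This size is only a floor, because compound 2 stands at a limit rather than a number: the limit of > 100000 nM in this assay, at which 2 of the 4 values shown sit.

On these data alone, what an amine or a longer chain at this position would give stays open. So does whether phenyl would have the same effect with methoxy in place of nitro.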